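Lengthening the Chain on a Weak Inhibitor

This account rests on a few compounds, and the source may have more. Where it says the series, first, only, none or still open, it means among the compounds named here.

In a functional assay on brain (Rattus norvegicus, strain Wistar) for inhibition (a lower number here means a stronger inhibitor, a higher number a weaker inhibitor), compound 1 `CCCCCCCCCCCCc1ccc(-c2c(C)[nH]c(=O)n2C)cc1` gives 13000 nM and compound 2 `CCCCCCCc1ccc(-c2c(C)[nH]c(=O)n2C2CCCCC2)cc1` gives 8700 nM. These two numbers lie within the usual scatter of each other, so compound 2 stands level with compound 1. The two compounds differ in both their chain and the other group on the shared core, so their values cannot separate the two changes.

Compound 3 `CCCCCCCCCCCCc1ccc(-c2c(C)[nH]c(=O)n2C2CCCCC2)cc1` keeps the cyclohexyl group of compound 2 and extends its chain. The change is pentyl in place of hydrogen on a saturated chain carbon, seven bonds along the chain from an aromatic carbon. This gives compound 3 the same long chain as compound 1, which lacks the cyclohexyl group. Compound 1 gives 13000 nM with that chain, so the longer chain looks tolerated and no large shift is expected. The estimate is a small move toward a lower number, a 1.7-fold lower number from compound 2 to compound 3 (0.24 log units; within the scatter), hardly beyond the scatter. For compound 3 the expected value in this assay is 5000 nM, with an estimated range from 1200 nM to 20000 nM.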

Compound 3, half-maximal inhibitory concentration: > 100000 nM
Compound 3: only a limit was reported (the forecaster's own chance of this, stated with the estimate: 8%); at least 20-fold (1.30 log units) between middle value and limit.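

In this assay compound 3 gives only a limit of the assay, not a number: (the limit of > 100000 nM in this assay, at which 1 of the 3 values shown sits). Even read as a limit, the result shows that this position does not accept every extension: pentyl in place of hydrogen on a saturated chain carbon, seven bonds along the chain from an aromatic carbon, makes a large step in the weaker direction while the cyclohexyl group stays in place (an at least 11-fold higher number from compound 2 to compound 3 (1.06 log units; beyond the scatter)). The long chain alone does not tell the whole story, as compound 1 carries the same chain with methyl on the aromatic nitrogen, and exchanging that methyl for cyclohexyl also moves the result beyond the scatter (an at least 7.6-fold higher number from compound 1 to compound 3 (0.88 log units; beyond the scatter)), so the long chain and the cyclohexyl group are tolerated apart but not together in these three compounds.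

The compounds shown leave open where along the way the loss sets in, which a chain of intermediate length on the cyclohexyl series could locate. They also leave open whether a chain ending in a carboxylic acid or an amine would fare any better at this position.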